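Replacing an ethyl group with an oxazole-bearing ether

The source may hold more compounds than are shown below. What is called first, only, known or untested is meant among the compounds shown, and "the series" means these compounds.

Of the compounds shown here, three have been measured in an assay for inhibition of kynurenine 3-monooxygenase (Homo sapiens), read by mass spectrometry, with a stated time of 1 h; a lower number here means a stronger inhibitor, a higher number a weaker inhibitor. Compound 1, `CCc1cc2oc(=O)n(CCC(=O)O)c2cc1Cl`, gives 10 nM in this assay. Compound 2, `Cc1ccc([C@@H](C)Oc2cc3onc(CCC(=O)O)c3cc2Cl)nn1`, gives 2 nM, and compound 3, `C[C@@H](Oc1cc2onc(CCC(=O)O)c2cc1Cl)c1ccc(F)cn1`, gives 3.16 nM. Compound 1 therefore stands highest of the three numbers: compound 3 is nearest to it, and compound 2 is furthest, both gaps lying beyond the scatter.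

The unmeasured compound 4, `C[C@@H](Oc1cc2oc(=O)n(CCC(=O)O)c2cc1Cl)c1ncco1`, differs from compound 1 in one place: a group of 8 heavy atoms (5 carbon, 1 nitrogen, 2 oxygen; one five-membered aromatic ring with 2 hetero atoms) in place of a group of 2 heavy atoms (2 carbon; no ring), on an aromatic carbon, ortho to a chloro group on the shared core of compound 1. Among the compounds with values here, the only single-change step available is a 1.6-fold higher number from compound 2 to compound 3 (0.20 log units; within the scatter), which swaps one aromatic ring for another on a saturated chain carbon bound to an oxygen on an aromatic ring and a saturated chain carbon. Compounds 2 and 3 sit on a different core from compound 1, so that step bears on the present change only loosely; it does show that the identity of the ring at that position matters little. Both compounds carrying such an ether group give lower numbers than compound 1, so a lower number is expected for compound 4 as well. The estimated step is a 3.3-fold lower number from compound 1 to compound 4 (0.52 log units; beyond the scatter). Compound 4 is expected to give about 3 nM, most likely between 1 nM and 10 nM.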

Compound 4, half-maximal inhibitory concentration: 3.16 nM
Compound 4: middle estimate off by 1.1-fold (0.02 log units), on the low side; low and high end bracket the measured number.
By their numbers in this assay, from the lowest: compounds 2, 3 and 4 (each within the scatter of the next); then compound 1.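

Compounds 2 and 3 carry an ether group only on a different core, so they could not show what such a group does on the core of compound 1; in this assay, the direct change now gives a 3.2-fold lower number from compound 1 to compound 4 (0.50 log units; beyond the scatter). This step is modest but lies beyond the scatter, and it shows that this aromatic carbon, ortho to a chloro group, accepts a group of 8 heavy atoms with a five-membered aromatic ring in place of an ethyl group of 2 heavy atoms, and that the number falls rather than rises. No measurement here accounts for this fall.

Several parts enter together in this single change (the ether oxygen, the branched carbon with its defined stereocentre and the ring), so the compounds shown do not tell which of them matters for the lower number. A plain methoxy group, a benzyloxy group and the mirror-image form of the group in compound 4 would separate these parts, and their numbers on this core remain an open question.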